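A Side-Chain Swap on the Amine Nitrogen of Compound 2

The source may hold more compounds than are shown below. What is called first, only, known or untested is meant among the compounds shown, and "the series" means these compounds.

Compound 2 `Cc1cn([C@@H]2O[C@H](CO[Si](C)(C)C(C)(C)C)[C@@]3(OS(=O)(=O)C=C3NCCC(N)=O)[C@H]2O[Si](C)(C)C(C)(C)C)c(=O)n(C)c1=O` carries a 2-carbamoylethyl group on an amine nitrogen of its shared core. In a functional assay on HEL cells (Homo sapiens) (a lower number here means that less compound is tolerated, a higher number that more compound is tolerated), compound 2 gives 14800 nM. Compound 1 `CCNC(=O)NC1=CS(=O)(=O)O[C@@]12[C@@H](CO[Si](C)(C)C(C)(C)C)O[C@@H](n1cc(C)c(=O)n(C)c1=O)[C@@H]2O[Si](C)(C)C(C)(C)C` carries an ethylcarbamoyl group in the same place, and in this assay compound 1 gives 10000 nM; the step between them is a 1.5-fold higher number from compound 1 to compound 2 (0.17 log units; within the scatter). Compound 3 `Cc1cn([C@@H]2O[C@@H]3COC(=O)[C@]3(OS(C)(=O)=O)[C@H]2O)c(=O)[nH]c1=O` lacks the bulky protecting groups of the other two, and in this assay compound 3 gives only a limit of the assay, >= 36000 nM, as recorded in the limit of >= 36000 nM in this assay, at which 1 of the 3 values shown sits. Among the numbers shown, compound 2 therefore stands highest of the two, with compound 1 nearest and within the scatter of it.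

Compound 4 `Cc1cn([C@@H]2O[C@H](CO[Si](C)(C)C(C)(C)C)[C@@]3(OS(=O)(=O)C=C3NCC(=O)C(=O)N3CCC3)[C@H]2O[Si](C)(C)C(C)(C)C)c(=O)n(C)c1=O` differs from compound 2 by ((azetidin-1-yl)carbonyl)carbonyl in place of carbamoylmethyl on a saturated chain carbon bound to an amine nitrogen. For the measured compounds named here, only one measured step bears on this change: a 1.5-fold higher number from compound 1 to compound 2 (0.17 log units; within the scatter) altered the same amine nitrogen and stayed within the scatter. Going by the values given here, no measured step introduces a ring or removes a hydrogen-bond donor at this position, so no clear direction can be read from the data, and the expected step is none beyond the scatter. Compound 4 is therefore expected to give about 15000 nM, with a likely range from 7000 nM to 36000 nM. The step this estimate means, a 1.0-fold higher number from compound 2 to compound 4 (0.01 log units; within the scatter), is expected to stay within the usual scatter.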

Compound 4, half-maximal cytotoxic concentration: 84400 nM
Beside the measured number, compound 4's estimate is 5.6-fold (0.75 log units) below it, outside the stated range (above it).
By their numbers in this assay, from the lowest: compounds 1 and 2 (each within the scatter of the next); then compound 4.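

In this assay, the side chain on this amine nitrogen can clearly change the number, which the earlier pair did not show: a 1.5-fold higher number from compound 1 to compound 2 (0.17 log units; within the scatter), whereas ((azetidin-1-yl)carbonyl)carbonyl in place of carbamoylmethyl gives a 5.7-fold higher number from compound 2 to compound 4 (0.76 log units; beyond the scatter). The comparison with the ethylcarbamoyl compound points the same way, with (((azetidin-1-yl)carbonyl)carbonyl)methyl in place of ethylcarbamoyl giving an 8.4-fold higher number from compound 1 to compound 4 (0.93 log units; beyond the scatter), so more compound is tolerated with the new group than with either earlier side chain. This single change brings in a four-membered ring, an extra carbonyl and a larger group, and removes a hydrogen-bond donor, and nothing measured here accounts for the rise.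

The compounds shown leave open which of these features carries the step: a pyrrolidine ring or an open-chain dimethylamino group in place of the azetidine ring would test the ring, while a side chain with a single carbonyl would test the second carbonyl. Also open, on these data alone, is whether the same step would appear on a core without the bulky protecting groups.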